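This account rests on a few compounds, and the source may have more. Where it says the series, first, only, none or still open, it means among the compounds named here.

In a functional assay on cells (Cancer cell lines, Homo sapiens) for inhibition (a higher number here means a weaker inhibitor of growth, a lower number a stronger inhibitor of growth), compound 1 `N=C(N)N/N=C/c1c(-c2cc(Cl)sc2Cl)nc2n1CCS2` gives 10500 nM and compound 2 `N=C(N)N/N=C/c1c(-c2ccsc2)nc2n1CCS2` gives 14500 nM, so these two values lie within the usual scatter of each other. Compound 3 `Cc1cc(-c2nc3n(c2/C=N/NC(=N)N)CCS3)c(C)s1` differs from compound 2 in one place: 2,5-dimethylthiophen-3-yl in place of thiophen-3-yl on an aromatic carbon. For the measured compounds named here, the one measured step that bears on this involves the same thiophen-3-yl group at the same place, with 2,5-dichlorothiophen-3-yl as its partner: a 1.4-fold higher number from compound 1 to compound 2 (0.14 log units; within the scatter). That step stays within the scatter, so no change beyond the scatter is expected in this assay, in either direction. The expected step is small: a 1.2-fold lower number from compound 2 to compound 3 (0.08 log units; within the scatter). For compound 3 the estimated value is 12000 nM, with an expected range of 6000 nM to 24000 nM.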

Compound 3, concentration for 50% growth inhibition: 24000 nM
Compound 3: the middle estimate sits 2.0-fold (0.30 log units) below what was measured, and the stated range covers the measured number.
By their numbers in this assay, from the lowest: compounds 1, 2 and 3 (each within the scatter of the next, the first and the last beyond it).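

In this assay, putting 2,5-dimethylthiophen-3-yl in place of thiophen-3-yl gives [ a 1.7-fold higher number from compound 2 to compound 3 (0.22 log units; within the scatter) ], so adding the two methyl groups leaves the number within the scatter. Putting it in place of 2,5-dichlorothiophen-3-yl gives [ a 2.3-fold higher number from compound 1 to compound 3 (0.36 log units; beyond the scatter) ], a modest step and the first at this position to go beyond the scatter, so methyl and chloro versions of the same ring can be told apart here. No supporting data explain this difference. As far as these compounds go, all three compounds carry a thiophene at this position, so the effect of a phenyl ring here remains open, as does that of an amine or a carboxylic acid on the ring.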